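A Fluorine on the Phenyl Ring of a Glycine Transporter Inhibitor

The source may hold more compounds than are shown below. What is called first, only, known or untested is meant among the compounds shown, and "the series" means these compounds.

The measurement throughout is an assay on cells for inhibition of sodium- and chloride-dependent glycine transporter 1 (Homo sapiens); a lower number here means that less compound is needed, a higher number that more compound is needed for the effect. Two compounds share one core and differ in a single place. Compound 1 `CN1CCCC(NC(=O)c2ccc(C(F)(F)F)cc2)(c2ccccc2)C1` gives only a limit of the assay in this assay, at > 10000 nM. Compound 2 `CN1CCCC(NC(=O)c2ccc(C(F)(F)F)cc2F)(c2ccccc2)C1` gives 9900 nM. The step of a number no higher from compound 1 to compound 2 (the limit leaves the size open) is the change (fluoro in place of hydrogen on an aromatic carbon); its size cannot be read because compound 1 sits at the limit of > 10000 nM in this assay, at which 1 of the 3 values shown sits.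

Compound 3 `COc1cc(C(F)(F)F)cc(SC)c1C(=O)NC1(c2ccccc2)CCCN(C)C1` stands on a different core, and how the two cores differ is not broken down here. In this assay compound 3 gives 24 nM, the lowest number among the measured compounds, with compound 2 the nearest at a far higher number.

Compound 4 `COc1cc(C(F)(F)F)cc(SC)c1C(=O)NC1(c2ccc(F)cc2)CCCN(C)C1` has not yet been measured. It differs from compound 3 by fluoro in place of hydrogen on an aromatic carbon, which at one bond further out reads phenyl to 4-fluorophenyl. This is the same kind of change as from compound 1 to compound 2, but not the same: there the fluoro entered ortho to a large group and meta to a trifluoromethyl group, here it enters para to a large group, on a ring on the other side of the amide.

Going by the values given here, since the one measured instance of this kind of change left its size unreadable, the expected step of a 1.0-fold higher number from compound 3 to compound 4 (0.02 log units; within the scatter) is set small, resting on compound 3 at 24 nM. Compound 4 is therefore expected at about 25 nM, between 8 nM and 80 nM.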

Compound 4, half-maximal effective concentration: 26 nM
Compound 4: middle estimate off by 1.0-fold (0.02 log units), on the low side; low and high end bracket the measured number.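

In this assay, placing a fluoro on the phenyl ring, para to a large group, gives a 1.1-fold higher number from compound 3 to compound 4 (0.03 log units; within the scatter). On this core, then, the change has no effect that can be told apart from the usual scatter, and that finding rests on this single pair. It does not show whether the change behaves the same way when carried from one core to another: the same change on two cores in this assay, a number no higher (the limit leaves the size open) from compound 1 to compound 2 and a 1.1-fold higher number (0.03 log units; within the scatter) from compound 3 to compound 4; the limit leaves it open whether they differ. Going by these compounds alone, compound 1 gives a limit of the assay and not a number, which leaves the earlier step unreadable, and the fluoro there also enters a different ring from the one it enters in compound 4: the limit of > 10000 nM in this assay, at which 1 of the 4 values shown sits.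

The compounds shown test only fluoro at this place on the phenyl ring, and what a chloro, a nitrile or a carboxylic acid would do there remains open. Going by these compounds, it is also open whether going from phenyl to 4-fluorophenyl on the core of compound 1 would read the same way as it does on the core of compound 3, a comparison that would need measured numbers on both cores rather than a limit.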